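This account rests on a few compounds, and the source may have more. Where it says the series, first, only, none or still open, it means among the compounds named here.

Compound 1, with the structure `FC(F)(F)c1ccc(/C=C\c2cc3ccccc3nc2Cl)cc1`, is examined in a functional assay on MCF7 cells (Homo sapiens) for antiproliferative activity, read by sulforhodamine B assay, with a stated time of 72 h (a higher number here means a weaker inhibitor, a lower number a stronger inhibitor), where compound 1 gives 4260 nM, the lowest of the two numbers measured. Going by the values given here, the only other measured compound is compound 2, `FC(F)(F)c1ccc(/C=C\c2cc3ccc(Cl)cc3nc2Cl)cc1`, which carries a chloro in place of hydrogen on an aromatic carbon of the shared core; in this assay compound 2 gives 6450 nM, and the step of a 1.5-fold higher number from compound 1 to compound 2 (0.18 log units; within the scatter) shows that this change leaves the read-out essentially unmoved.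

The compound not yet measured is compound 3, `FC(F)(F)c1ccc(/C=C\c2cc3ccccc3nc2Cl)c(C(F)(F)F)c1`. It differs from compound 1 in one place: trifluoromethyl in place of hydrogen on an aromatic carbon. The new group sits on the six-membered aromatic ring of carbon only, ortho to a large group and meta to a trifluoromethyl group. Among the compounds with values here, no measured step touches this ring; the step from compound 1 to compound 2 concerns a different part of the molecule, so it offers only indirect guidance that a single small added group at a distant site changed little. Within the data shown here, with no direct precedent, the expected step is a 1.2-fold higher number from compound 1 to compound 3 (0.07 log units; within the scatter), that is, no shift beyond the scatter. The estimate for compound 3 in this assay is therefore 5000 nM, within a range from 1500 nM to 16000 nM.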

Compound 3, half-maximal inhibitory concentration: 10500 nM
For compound 3 the middle estimate is 2.1-fold (0.32 log units) below the measured one, within the range that was stated.
By their numbers in this assay, from the lowest: compounds 1, 2 and 3 (each within the scatter of the next, the first and the last beyond it).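

In this assay, trifluoromethyl on the six-membered aromatic ring of carbon only, ortho to a large group and meta to a trifluoromethyl group, gives a 2.5-fold higher number from compound 1 to compound 3 (0.39 log units; beyond the scatter), a modest weakening and the only step shown here that lies beyond the scatter. This position therefore does not tolerate every change without consequence: the chloro step elsewhere on the shared core left the number essentially unmoved, whereas this group of 4 heavy atoms moves it measurably, although the two steps differ in both the group and the place, so they cannot separate these two factors. Nothing in the data shown accounts for the rise in the number.

From the compounds shown here alone, one group at one position cannot show how this place responds to substituents in general, so it remains open whether a smaller fluoro or methyl group here would also raise the number, or whether a methoxy, an amine or a carboxylic acid would shift it differently. Going by these compounds, it is also open whether the same trifluoromethyl group on another carbon of this ring would give a similar step.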